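Fluorophenyl change from compound 2 to compound 3

The source may report more compounds than this note shows. Statements on the series, on what has been measured and on what is new or still open speak of the compounds shown alone.

Measured so far in a functional assay, with a stated time of 6 min; on this read-out lower numbers stand for stronger inhibition and higher numbers for weaker inhibition:
- compound 1 `CCOc1ccccc1NCn1nc(-c2ccc3c(c2)OCCO3)oc1=S` gives 5280 nM
- compound 2 `Fc1ccccc1NCn1nc(-c2ccc3c(c2)OCCO3)oc1=S` gives 6390 nM

Compound 2 stands level with compound 1, since the two numbers are not separated beyond the scatter. Among the measured compounds shown here, the only measured step, a 1.2-fold higher number from compound 1 to compound 2 (0.08 log units; within the scatter), puts fluoro in place of ethoxy on an aromatic carbon.

The next compound is compound 3 `Fc1ccc(NCn2nc(-c3ccc4c(c3)OCCO4)oc2=S)cc1`, which carries 4-fluorophenyl in place of 2-fluorophenyl on an amine nitrogen. For the measured compounds named here, no measured step covers this change directly. Going by the values given here, the one available precedent is the small step of a 1.2-fold higher number from compound 1 to compound 2 (0.08 log units; within the scatter), which gives no reason to expect a shift in either direction. In this assay, no step beyond the scatter is therefore expected, and the expected step is a 1.1-fold lower number from compound 2 to compound 3 (0.03 log units; within the scatter). For compound 3 the estimated value is 6000 nM, with an expected range of 2500 nM to 14000 nM.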

Compound 3, half-maximal inhibitory concentration: 6480 nM
Estimate against measurement, compound 3: 1.1-fold (0.03 log units) below; the range from low to high includes it.
By their numbers in this assay, from the lowest: compounds 1, 2 and 3 (each within the scatter of the next).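

Both positions of the fluorine on the phenyl ring are now covered, and in this assay 2-fluorophenyl and 4-fluorophenyl on the amine nitrogen cannot be told apart (a 1.0-fold higher number from compound 2 to compound 3 (0.01 log units; within the scatter)). The replacement of 2-ethoxyphenyl by 4-fluorophenyl at the same nitrogen also stays within the scatter (a 1.2-fold higher number from compound 1 to compound 3 (0.09 log units; within the scatter)), so the three aryl groups give no order at this position, and the earlier single step now has two further steps beside it showing the same flat picture. No supporting measurement bears on this result.

Going by these compounds, whether any group on this amine nitrogen can move the value beyond the scatter stays open, for example a carboxylic acid or an amine on the phenyl ring, or a longer chain in its place. On these data alone, how far changes to the shared core would shift the value also remains unknown.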